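Aryl swap on the amino side of the shared core

The source may hold more compounds than are shown below. What is called first, only, known or untested is meant among the compounds shown, and "the series" means these compounds.

Measured so far:
- compound 1 `COc1cc(NC(=O)Nc2cc(Nc3ccc(C)c(C)c3)ncn2)cc(OC)c1` gives 20.1% in a functional assay on NCI-H1581 cells (Homo sapiens) for inhibition, read by MTT assay, with a stated time of 48 h, tested at 10 uM; on this read-out lower numbers stand for less inhibition and higher numbers for more inhibition at the one concentration tested (going by the name of the read-out)
- compound 2 `COc1cc(Nc2cc(NC(=O)Nc3c(Cl)cccc3Cl)ncn2)cc(OC)c1` gives 68% in this assay

Among the measured compounds shown here, compound 1 stands lowest of the two numbers known; compound 2 lies higher by a gap beyond the scatter, but no single step links the two, so their values are noted side by side and nothing more. Compound 3 `COc1cc(NC(=O)Nc2cc(Nc3ccc(Br)cc3OC)ncn2)cc(OC)c1` is not yet measured. It differs from compound 1 in one place: 4-bromo-2-methoxyphenyl in place of 3,4-dimethylphenyl on a nitrogen on an aromatic ring. For the measured compounds named here, no measured pair shows this change, and the value of compound 2 says nothing direct about it. With compound 1 as the only anchor, a modest rise in this assay is expected, or none beyond the scatter; the expected step is a number 9.9 percentage points higher from compound 1 to compound 3 (within the scatter). Compound 3 is accordingly estimated at 30%, with a range from 10% to 55%.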

Compound 3, a percentage reported as inhibition, at one concentration (the size of the read-out at that concentration, not a potency): 20.1%
Compound 3: middle estimate off by 9.9 percentage points, on the high side, within the range that was stated.
By their numbers in this assay, from the lowest: compounds 1 and 3 (each within the scatter of the next); then compound 2.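

Among the compounds shown here, on the amino side of the shared core, the change from 3,4-dimethylphenyl to 4-bromo-2-methoxyphenyl gives the first single-place step at this position in this assay: no change at the digits printed from compound 1 to compound 3 (within the scatter). The entering group brings bromine, a methoxy group and a hydrogen-bond acceptor that the leaving group lacks, yet at the one concentration tested the read-out does not separate the two aryl groups. No supporting data are at hand to explain this outcome.

Still open, on these data alone, is how this nitrogen responds to a phenyl group carrying an amine or a carboxylic acid, substituents unlike those in the two aryl groups compared here. Also open, as far as these compounds go, is whether this aryl exchange would again leave the read-out unmoved with a different group at the other end of the shared core.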